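Working notes: from compound 1 toward compound 4

A few compounds are considered here, and "the series" means these few. Any claim that something is new, unique, unknown or untested is made for them only; others in the source may bear on it.

Measured so far, in an assay on CHO cells for displacement of a labelled ligand from adenosine receptor A3 (Homo sapiens), read by scintillation counting, with a stated time of 45 min, in the presence of a further agent that is not named here; a higher number here means a weaker inhibitor, a lower number a stronger inhibitor:
compound 1, `CCCn1c(=O)[nH]c2nc(-c3ccc(S(=O)(=O)N4CCN(c5ccc(Br)cc5)CC4)cc3)[nH]c2c1=O`: > 1000 nM
compound 2, `CCCn1c(=O)[nH]c2nc(-c3ccc(S(=O)(=O)N4CCN(Cc5cccc(C)c5)CC4)cc3)[nH]c2c1=O`: > 1000 nM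
compound 3, `CCCn1c(=O)[nH]c2nc(-c3ccc(S(=O)(=O)N4CCN(c5cccc(F)c5)CC4)cc3)[nH]c2c1=O`: > 1000 nM

Each of these three values is a limit of this assay, not a number. Compound 1 therefore has no measured place on a scale; it sits at the limit of > 1000 nM in this assay, at which 3 of the 3 values shown sit, together with the other two. The steps a step that the two limits leave unreadable from compound 1 to compound 2, a step that the two limits leave unreadable from compound 1 to compound 3 and a step that the two limits leave unreadable from compound 2 to compound 3 are all hidden by that limit, so no size or direction can be read from any of them.

Compound 4, `CCCn1c(=O)[nH]c2nc(-c3ccc(S(=O)(=O)N4CCN(c5ccc(I)cc5)CC4)cc3)[nH]c2c1=O`, differs from compound 1 by iodo in place of bromo on an aromatic carbon; cut one bond further out, 4-bromophenyl becomes 4-iodophenyl. The measured steps bear on this change only in so far as every variation tried on the amine nitrogen in the ring has remained at the limit. No step beyond the scatter is expected in this assay, in either direction. Compound 4 is therefore expected to give about 3000 nM, within 1000 nM to 20000 nM, most likely again as a limit. The expected step is a step that the limit leaves unreadable from compound 1 to compound 4.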

Compound 4, inhibition constant: > 1000 nM
Compound 4: a limit, no number; the forecaster's own chance of this, stated with the estimate: 80%; the middle value does not contradict the limit.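

In this assay compound 4 gives > 1000 nM, a limit and not a number. No step from compound 1, compound 2 or compound 3 to compound 4 can be read, and all four compounds share one position: the limit of > 1000 nM in this assay, at which 4 of the 4 values shown sit.

The compounds shown leave open how far each lies beyond that limit, and whether any group on the amine nitrogen in the ring gives a measurable value.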